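Branching the Ketone Chain in a Second Core

The compounds below may be only part of what the source reports. "The series", "measured", "known", "first", "only" and "open" are said of these compounds alone.

Measured compounds:
compound 1, `CCCC(=O)c1ccc(OCCCCOc2cccc(C(=O)O)c2C)c(C)c1O`, 52 nM
compound 2, `Cc1c(OCCCCOc2ccc(C(=O)C(C)C)c(O)c2C)cccc1C(=O)O`, 149 nM
compound 3, `CCCC(=O)c1ccc(OCCCCOc2cc(C(=O)O)ccc2OC)c(C)c1O`, 103 nM

All three were measured in an assay on HEK293 cells for positive allosteric modulation of metabotropic glutamate receptor 2 (Rattus norvegicus), read by thallium flux, with a stated time of 2.5 min; a higher number here means that more compound is needed for the effect, a lower number that less compound is needed. Compound 1 and compound 2 share one core and differ in a single place: isopropyl in place of propyl on a carbonyl carbon. Along this change the number rises, a 2.9-fold higher number from compound 1 to compound 2 (0.46 log units; beyond the scatter).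

Compound 3 carries a different core. How its core differs from that of compound 1 is not broken down here. Compound 3 and compound 2 give values that lie within the usual scatter of each other, as do compound 3 and compound 1, so no order among them can be claimed.

Compound 4, `COc1ccc(C(=O)O)cc1OCCCCOc1ccc(C(=O)C(C)C)c(O)c1C`, has not yet been measured. It differs from compound 3 in exactly the same way that compound 2 differs from compound 1: isopropyl in place of propyl on a carbonyl carbon. The place is the same in both pairs, a carbonyl carbon whose other neighbour is an aromatic carbon, so the change is the same, not merely the same kind.

Among the measured compounds shown here, because the only measured example of this change, a 2.9-fold higher number from compound 1 to compound 2 (0.46 log units; beyond the scatter), raised the number by a modest amount beyond the scatter, a step of similar size is expected from compound 3 to compound 4, a 2.9-fold higher number from compound 3 to compound 4 (0.46 log units; beyond the scatter). This rests on a single pair, so the expectation is uncertain. Starting from compound 3 at 103 nM, compound 4 is estimated at 300 nM, with a likely range from 150 nM to 600 nM.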

Compound 4, half-maximal effective concentration: 116 nM
Beside the measured number, compound 4's estimate is 2.6-fold (0.41 log units) above it; the whole stated range lies above it.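

In this assay, among the compounds shown here, isopropyl in place of propyl on the carbonyl carbon gives a 1.1-fold higher number from compound 3 to compound 4 (0.05 log units; within the scatter), so on the core of compound 3 this change produces no step that can be told apart from repeat-measurement noise. Setting this result beside the earlier step shows that the apparent difference in behaviour on the two cores is no larger than the noise expected when two such steps are compared: the same change on two cores in this assay, a 2.9-fold higher number (0.46 log units; beyond the scatter) from compound 1 to compound 2 and a 1.1-fold higher number (0.05 log units; within the scatter) from compound 3 to compound 4, 2.5-fold (0.41 log units) apart, within the scatter of two such steps. For the compounds shown here, this does not show that the change has the same effect on both cores, nor that the core alters its effect, since each core offers only a single pair, and a clear step on one core beside an unreadable step on the other could reflect either a shared modest effect or a real difference that these few numbers are too noisy to resolve.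

The compounds shown leave open how a cyclopropyl or tert-butyl group on that carbonyl carbon would behave on either core, and whether a longer chain such as pentyl would move the number further. They also leave open whether the propyl-to-isopropyl change would give a readable step on a third core, for instance one carrying an amide in place of the carboxylic acid.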